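The compounds below may be only part of what the source reports. "The series", "measured", "known", "first", "only" and "open" are said of these compounds alone.

Measured so far:
- compound 1 `Cc1nc(-c2ccsc2)cc2nn(-c3ccccc3)cc12`: 10000 nM in a functional assay on K562 cells (Homo sapiens) for inhibition, read by fluorescence, with a stated time of 72 h; a lower number here means a stronger inhibitor of growth, a higher number a weaker inhibitor of growth
- compound 2 `CCCCc1cc2nn(-c3ccccc3)cc2c(C)n1`: 8500 nM in this assay

Going by the values given here, compound 2 and compound 1 lie within the scatter of each other in this assay; the only measured step, a 1.2-fold lower number from compound 1 to compound 2 (0.07 log units; within the scatter), is itself within the scatter. Compound 3 `CCCCCc1cc2nn(-c3ccccc3)cc2c(C)n1` differs from compound 2 by methyl in place of hydrogen on a saturated chain carbon, four bonds along the chain from an aromatic carbon. Among the compounds with values here, no measured step covers chain lengthening, so nothing indicates a shift beyond the scatter in this assay. Compound 3 is therefore expected near compound 2, an estimated no change at the digits printed from compound 2 to compound 3 (within the scatter), giving an expected 8500 nM with a range of 4000 nM to 20000 nM.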

Compound 3, concentration for 50% growth inhibition: 6900 nM
For compound 3 the middle estimate is 1.2-fold (0.09 log units) above the measured one, within the range that was stated.
By their numbers in this assay, from the lowest: compounds 3, 2 and 1 (each within the scatter of the next).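

In this assay, methyl in place of hydrogen on a saturated chain carbon, four bonds along the chain from an aromatic carbon, gives a 1.2-fold lower number from compound 2 to compound 3 (0.09 log units; within the scatter) and so provides the first measured chain lengthening, which stays within the scatter. Swapping the thiophen-3-yl group for a pentyl chain gives a 1.4-fold lower number from compound 1 to compound 3 (0.16 log units; within the scatter) and also stays within the scatter, as butyl did. No supporting evidence bears on these results.

Still open, from the compounds shown here alone, is whether a longer chain at this position would give a step beyond the scatter. Going by these compounds, an amine or a carboxylic acid on the chain is equally open.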